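From 4-bromophenyl to 2-ethoxyphenyl on the shared core

The source may report more compounds than this note shows. Statements on the series, on what has been measured and on what is new or still open speak of the compounds shown alone.

In a functional assay on HeLa cells (Homo sapiens) for inhibition, read by sulforhodamine B assay (on this read-out lower numbers stand for stronger inhibition and higher numbers for weaker inhibition), compound 1 `CCCc1ccc(NC2=CC(=O)c3nc4n(c3C2=O)[C@H]2OC[C@@H](O)[C@H]2OC4)cc1` gives 4990 nM and compound 2 `O=C1C=C(Nc2ccc(Br)cc2)C(=O)c2c1nc1n2[C@H]2OC[C@@H](O)[C@H]2OC1` gives 3830 nM, so compound 2 stands within the scatter of compound 1. Compound 3 `CCOc1ccccc1NC1=CC(=O)c2nc3n(c2C1=O)[C@H]1OC[C@@H](O)[C@H]1OC3` differs from compound 2 as follows: 2-ethoxyphenyl in place of 4-bromophenyl on an amine nitrogen. In words, it has 2-ethoxyphenyl in place of 4-bromophenyl on an amine nitrogen. Among the measured compounds shown here, the only measured step, a 1.3-fold lower number from compound 1 to compound 2 (0.11 log units; within the scatter), bears on this loosely, and no measured compound carries 2-ethoxyphenyl. No change beyond the scatter is therefore expected in this assay, in either direction. The estimated step is a 1.0-fold higher number from compound 2 to compound 3 (0.02 log units; within the scatter). For compound 3 the expected value is 4000 nM, with an estimated range of 1500 nM to 11000 nM.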

Compound 3, half-maximal inhibitory concentration: 6040 nM
For compound 3 the middle estimate is 1.5-fold (0.18 log units) below the measured one; low and high end bracket the measured number.
By their numbers in this assay, from the lowest: compounds 2, 1 and 3 (each within the scatter of the next).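

In this assay, 2-ethoxyphenyl in place of 4-bromophenyl on the amine nitrogen gives a 1.6-fold higher number from compound 2 to compound 3 (0.20 log units; within the scatter), and 2-ethoxyphenyl in place of 4-propylphenyl gives a 1.2-fold higher number from compound 1 to compound 3 (0.08 log units; within the scatter). Among these three compounds, then, no step at this amine nitrogen goes beyond the scatter, even with 2-ethoxyphenyl, the one group of the three that carries a hydrogen-bond acceptor. No measured evidence bears on this result. Going by these compounds, it remains open whether an amine or a carboxylic acid on the phenyl ring, or a longer chain in place of the ethoxy group, would give a step beyond the scatter.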